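Iodo for nitro at the aryl carbon in a thiosemicarbazone series

The source may report more compounds than this note shows. Statements on the series, on what has been measured and on what is new or still open speak of the compounds shown alone.

Three members of the series have numbers in a functional assay on T98G cells (Homo sapiens) for cytotoxicity, read by MTT assay, with a stated time of 48 h; a lower number here means a stronger inhibitor, a higher number a weaker inhibitor: compound 1 `C/C(=N/NC(=S)Nc1ccccc1I)c1ccccn1` gives 8.09 nM, compound 2 `CC(=NNC(=S)Nc1ccccc1F)c1ccccn1` gives 3.1 nM, and compound 3 `CC(=NNC(=S)Nc1ccccc1[N+](=O)[O-])c1ccccn1` gives 6.6 nM. Going by the values given here, compound 3 stands second highest of the three, nearest to compound 1 and furthest from compound 2; the only measured single-point step is a 2.1-fold higher number from compound 2 to compound 3 (0.33 log units; beyond the scatter), a modest move beyond the scatter.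

Compound 4 `CC(=NNC(=S)Nc1ccccc1I)c1ccccn1` differs from compound 3 at one place: iodo in place of nitro on an aromatic carbon. Among the compounds with values here, no measured step swaps iodo for nitro directly. The step from compound 2 to compound 3 shows that an exchange at this carbon can shift the number by a modest amount. Compound 1 also carries iodo on the same aromatic carbon and gives 8.09 nM, which sits within the scatter of compound 3.

The expected change is therefore small, at most a slight rise, a 1.2-fold higher number from compound 3 to compound 4 (0.08 log units; within the scatter), not clearly beyond the scatter. Compound 4 is estimated at 8 nM, with a range from 4 nM to 16 nM.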

Compound 4, half-maximal inhibitory concentration: 8.1 nM
Compound 4: the middle estimate sits 1.0-fold (0.01 log units) below what was measured; measured number inside the range.
By their numbers in this assay, from the lowest: compound 2; then compounds 3, 1 and 4 (each within the scatter of the next).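

In this assay, iodo in place of nitro on this aromatic carbon gives a 1.2-fold higher number from compound 3 to compound 4 (0.09 log units; within the scatter), so the two groups are not separated here, although nitro brings 3 heavy atoms and iodo 1. Iodo in place of fluoro gives a 2.6-fold higher number from compound 2 to compound 4 (0.42 log units; beyond the scatter), a modest step in the same direction as the earlier nitro for fluoro step, so fluoro stands apart from both nitro and iodo at this carbon. The same atoms and bonds, drawn in two ways, read alike, with a 1.0-fold higher number from compound 1 to compound 4 (0.00 log units; within the scatter), and the drawing is all that separates the pair: the fact that one of compounds 1 and 4 is drawn with a defined configuration and the other without, at the place where they differ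

On these data alone, whether an amine, a methoxy group or a carboxylic acid on this aromatic carbon would read with fluoro or with nitro and iodo remains open. Also open, as far as these compounds go, is whether the double bond left undefined in compound 4 has the Z configuration drawn in compound 1.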